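The compounds below may be only part of what the source reports. "The series", "measured", "known", "first", "only" and "open" are said of these compounds alone.

Three compounds share the same long chain ending in a nitro-bearing core, and differ only in the aryl group carried on the amide nitrogen. Compound 1 `O=C(CCC(=O)OCCCCCCSc1ccc([N+](=O)[O-])c2nonc12)Nc1ccccc1Cl` carries a 2-chlorophenyl group there; in a functional assay on 143B cells (Homo sapiens) for inhibition, read by MTT assay, with a stated time of 72 h (on this read-out lower numbers stand for stronger inhibition and higher numbers for weaker inhibition), compound 1 gives 2430 nM. Compound 2 `COc1ccccc1NC(=O)CCC(=O)OCCCCCCSc1ccc([N+](=O)[O-])c2nonc12` carries a 2-methoxyphenyl group, and in this assay compound 2 gives 2120 nM. Compound 3 `O=C(CCC(=O)OCCCCCCSc1ccc([N+](=O)[O-])c2nonc12)Nc1ccc(Br)cc1` carries a 4-bromophenyl group, and in this assay compound 3 gives 2710 nM. Compound 2 has the lowest of the three numbers, but the gaps are small: a 1.1-fold lower number from compound 1 to compound 2 (0.06 log units; within the scatter), and a 1.3-fold higher number from compound 2 to compound 3 (0.11 log units; within the scatter), so all three sit together within the usual scatter.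

Compound 4 `COc1ccc(NC(=O)CCC(=O)OCCCCCCSc2ccc([N+](=O)[O-])c3nonc23)cc1OC` is compound 2 with 3,4-dimethoxyphenyl in place of 2-methoxyphenyl on an amide-type nitrogen. The steps that speak to this change are a 1.1-fold lower number from compound 1 to compound 2 (0.06 log units; within the scatter), which swapped one small group on the ring, and a 1.3-fold higher number from compound 2 to compound 3 (0.11 log units; within the scatter) together with a 1.1-fold higher number from compound 1 to compound 3 (0.05 log units; within the scatter), which swapped the whole aryl group. None of them moved the number beyond the scatter. Adding a second methoxy group and moving the substitution around the ring is therefore expected to give no step beyond the scatter in this assay, so that compound 4 is expected to show a 1.1-fold higher number from compound 2 to compound 4 (0.04 log units; within the scatter). On that basis compound 4 is estimated at 2300 nM, with a range from 1300 nM to 4200 nM.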

Compound 4, half-maximal inhibitory concentration: 2770 nM
Compound 4: middle estimate off by 1.2-fold (0.08 log units), on the low side; the range from low to high includes it.
By their numbers in this assay, from the lowest: compounds 2, 1, 3 and 4 (each within the scatter of the next).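

Putting 3,4-dimethoxyphenyl in place of 2-methoxyphenyl on the amide-type nitrogen brings in 10 heavy atoms instead of 8 and 2 hydrogen-bond acceptors instead of 1, yet in this assay the result is small (a 1.3-fold higher number from compound 2 to compound 4 (0.12 log units; within the scatter)). Set against the halogen-bearing rings, the picture is the same (a 1.0-fold higher number from compound 3 to compound 4 (0.01 log units; within the scatter)) and (a 1.1-fold higher number from compound 1 to compound 4 (0.06 log units; within the scatter)), so all four compounds remain within the scatter of one another. The earlier compounds each carried a single group on the ring, whereas compound 4 shows that a ring with two methoxy groups at this position also gives no step beyond the scatter, and no measurement here offers an explanation for this flat result.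

From the compounds shown here alone, all four compounds carry a substituted phenyl ring on this nitrogen, so it remains open whether an amine or a carboxylic acid on that ring, or a plain alkyl chain in place of the ring, would move the number beyond the scatter. The chain and the core are also the same throughout, which leaves open how a shorter chain or an amide in place of the ester would behave.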